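From 2,4-dihydroxyphenyl to thiophen-2-yl on a shared core

The source may hold more compounds than are shown below. What is called first, only, known or untested is meant among the compounds shown, and "the series" means these compounds.

In a functional assay on HCT-116 cells (Homo sapiens) for inhibition, read by MTT assay, with a stated time of 48 h (a lower number here means a stronger inhibitor, a higher number a weaker inhibitor), compound 1 (`COc1cc(-c2cc(-c3ccc(Cl)cc3)nc(-c3ccccc3)n2)cc(OC)c1OC`) gives 7980 nM, compound 2 (`COc1cc(-c2cc(-c3ccc(C)cc3)nc(-c3ccccc3)n2)cc(OC)c1OC`) gives 15700 nM and compound 3 (`COc1cc(-c2cc(-c3ccc(O)cc3O)nc(-c3ccccc3)n2)cc(OC)c1OC`) gives 5890 nM. Compound 3 therefore matches compound 1 within the scatter, as the comparison shows: a 1.4-fold lower number from compound 1 to compound 3 (0.13 log units; within the scatter). It clearly beats only compound 2: a 2.7-fold lower number from compound 2 to compound 3 (0.43 log units; beyond the scatter). Compound 4 (`COc1cc(-c2cc(-c3cccs3)nc(-c3ccccc3)n2)cc(OC)c1OC`) has thiophen-2-yl in place of 2,4-dihydroxyphenyl on an aromatic carbon. The three measured steps all change the group at this same carbon, and they stay small, including a 2.0-fold higher number from compound 1 to compound 2 (0.29 log units; within the scatter). Within the data shown here, no thiophen-2-yl group has yet been measured, so only a small upward move, towards the values of compound 1 and compound 2, is expected. The estimated change is a 1.7-fold higher number from compound 3 to compound 4 (0.23 log units; within the scatter). For compound 4 the expected value is 10000 nM, within an estimated range of 4500 nM to 22000 nM.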

Compound 4, half-maximal inhibitory concentration: 17000 nM
Compound 4: the middle estimate sits 1.7-fold (0.23 log units) below what was measured; the range from low to high includes it.
By their numbers in this assay, from the lowest: compounds 3, 1, 2 and 4 (each within the scatter of the next, the first and the last beyond it).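

In this assay, this carbon does not accept every aromatic ring equally: thiophen-2-yl, a five-membered ring with sulfur, loses ground against 2,4-dihydroxyphenyl (a 2.9-fold higher number from compound 3 to compound 4 (0.46 log units; beyond the scatter)). It also loses ground against 4-chlorophenyl (a 2.1-fold higher number from compound 1 to compound 4 (0.33 log units; beyond the scatter)). Against 4-methylphenyl it cannot be told apart (a 1.1-fold higher number from compound 2 to compound 4 (0.03 log units; within the scatter)), so a ring with no hydrogen-bond donors can sit level with a six-membered carbon ring that also has none.

As far as these compounds go, whether an amine or a carboxylic acid on the ring at this carbon would bring a larger change remains open. Nothing available here explains these differences.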